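This account rests on a few compounds, and the source may have more. Where it says the series, first, only, none or still open, it means among the compounds named here.

Measured in an ADME assay on MT4 cells (Homo sapiens) for cytotoxicity, read by MTT assay, with a stated time of 4 days; a higher number here means that more compound is tolerated, a lower number that less compound is tolerated:
compound 1 `Cc1cccc(NC(=O)CS(=O)(=O)c2nccc(Oc3c(C)cc(C#N)cc3C)n2)c1`, 25700 nM
compound 2 `Cc1ccc(NC(=O)CS(=O)(=O)c2nccc(Oc3c(C)cc(C#N)cc3C)n2)cc1`, 7490 nM
compound 3 `Cc1cc(C#N)cc(C)c1Oc1ccnc(S(=O)(=O)CC(=O)Nc2ccc(Cl)c(Cl)c2)n1`, 11700 nM

Compound 3 stands second highest of the three numbers in this assay. Its nearest neighbour is compound 2, with a 1.6-fold higher number from compound 2 to compound 3 (0.19 log units; within the scatter), and its furthest is compound 1, with a 2.2-fold lower number from compound 1 to compound 3 (0.34 log units; beyond the scatter). Compound 4 `Cc1cc(C#N)cc(C)c1Oc1ccnc(S(=O)(=O)CC(=O)Nc2cccc([N+](=O)[O-])c2)n1` differs from compound 3 by 3-nitrophenyl in place of 3,4-dichlorophenyl on an amide-type nitrogen. Every measured step exchanges the aryl group on that same amide nitrogen: a 3.4-fold lower number from compound 1 to compound 2 (0.54 log units; beyond the scatter), a 2.2-fold lower number from compound 1 to compound 3 (0.34 log units; beyond the scatter) and a 1.6-fold higher number from compound 2 to compound 3 (0.19 log units; within the scatter). Within the data shown here, no measured compound carries a nitrophenyl group, so the new step can only be read against these modest aryl swaps. A modest step in either direction, or none beyond the scatter, is therefore expected in this assay. The estimate for compound 4 is 10000 nM, with a range from 4000 nM to 30000 nM. This expected value corresponds to a 1.2-fold lower number from compound 3 to compound 4 (0.07 log units; within the scatter).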

Compound 4, half-maximal cytotoxic concentration: 23600 nM
Compound 4: the middle estimate sits 2.4-fold (0.37 log units) below what was measured; the measured number falls inside the stated range.
By their numbers in this assay, from the lowest: compounds 2, 3, 4 and 1 (each within the scatter of the next, the first and the last beyond it).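

Nitro in place of methyl gives a 1.1-fold lower number from compound 1 to compound 4 (0.04 log units; within the scatter) and so no readable change in this assay on this amide nitrogen. Against 3,4-dichlorophenyl the step is a 2.0-fold higher number from compound 3 to compound 4 (0.30 log units; within the scatter) and only 4-methylphenyl stands apart, with a 3.2-fold higher number from compound 2 to compound 4 (0.50 log units; beyond the scatter) in this set, so the two hydrogen-bond acceptors of 3-nitrophenyl come without a loss in tolerated concentration here. No measurement at hand accounts for these steps.

Open, going by these compounds, is whether an amine or a carboxylic acid in place of the nitro stays level with compound 4. Also open, on these data alone, is whether 4-nitrophenyl on the same nitrogen falls toward the number of compound 2.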